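Fluoro to bromo on compound 2

The source may hold more compounds than are shown below. What is called first, only, known or untested is meant among the compounds shown, and "the series" means these compounds.

In an ADME assay on L6 cells (Rattus norvegicus) for cytotoxicity, read by resazurin assay, with a stated time of 72 h (a higher number here means a weaker inhibitor, a lower number a stronger inhibitor), compound 1 `OC(c1ccc(Cl)cc1)(c1cncnc1)c1cccc(F)c1` gives > 100000 nM, which is a limit of the assay. Compound 2 `OC(c1ccc(Cl)cc1)(c1cccnc1)c1cccc(F)c1` gives 66000 nM and compound 3 `COC(c1ccc(Cl)cc1)(c1cccnc1)c1ccccc1Cl` gives 58700 nM, two values within the scatter of each other.

Compound 4 `OC(c1ccc(Cl)cc1)(c1cccnc1)c1cccc(Br)c1` differs from compound 2 by bromo in place of fluoro on an aromatic carbon, that is, 3-fluorophenyl to 3-bromophenyl. Going by the values given here, the only measured step is an at least 1.5-fold lower number from compound 1 to compound 2 (0.18 log units; that floor lies within the scatter). That step lies at a different place in the structure and does not touch the halogen, so it bears on the new change only weakly. Among the compounds with values here, no measured step exchanges this fluoro for another halogen.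

The expectation therefore rests on compound 2 at 66000 nM: no step beyond the scatter is expected in this assay, with a slight lean towards a lower number. The estimated step is a 1.3-fold lower number from compound 2 to compound 4 (0.12 log units; within the scatter). Compound 4 is expected at 50000 nM, with an estimated range from 22000 nM to 95000 nM.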

Compound 4, half-maximal inhibitory concentration: 54100 nM
Compound 4: the middle estimate sits 1.1-fold (0.03 log units) below what was measured; measured number inside the range.
By their numbers in this assay, from the lowest: compounds 4, 3 and 2 (each within the scatter of the next). At a limit, above all of these: compound 1.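

In this assay, going by these compounds alone, the halogen on the 3-fluorophenyl ring is varied here for the first time, and the exchange gives a 1.2-fold lower number from compound 2 to compound 4 (0.09 log units; within the scatter). Within this pair, therefore, bromo and fluoro on this aromatic carbon cannot be told apart by this read-out, and the earlier step, at a different place in the structure, could not show this. Compound 1 alone stands at a limit: the limit of > 100000 nM in this assay, at which 1 of the 4 values shown sits.

The compounds shown say nothing about a group of a different kind at this aromatic carbon, such as an amine, a carboxylic acid or a longer chain, so it remains unknown whether this position can shift the number beyond the scatter. They also leave open whether a change at this position would act in the same way on the core of compound 1.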